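Iodo to trifluoromethyl in a level series

This account rests on a few compounds, and the source may have more. Where it says the series, first, only, none or still open, it means among the compounds named here.

compound 1 `Cc1cc2c(cc1C)C(Cl)=C(c1nnc(-c3ccccc3)o1)CCC2`: 4120 nM
compound 2 `Cc1cc2c(cc1C)C(Cl)=C(c1nnc(-c3cccc(Cl)c3)o1)CCC2`: 4570 nM
compound 3 `Cc1cc2c(cc1C)C(Cl)=C(c1nnc(-c3cccc(I)c3)o1)CCC2`: 4120 nM

In a functional assay on PANC-1 cells (Homo sapiens) for antiproliferative activity, read by sulforhodamine B assay, with a stated time of 48 h (on this read-out higher numbers stand for weaker inhibition of growth and lower numbers for stronger inhibition of growth), compound 3 gives 4120 nM, level with compound 1 and within the scatter of compound 2, so these three cannot be ranked. The next case is compound 4 `Cc1cc2c(cc1C)C(Cl)=C(c1nnc(-c3cccc(C(F)(F)F)c3)o1)CCC2`, and the structural change is trifluoromethyl in place of iodo on an aromatic carbon.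

Among the compounds with values here, three measured steps bear on this, each a swap on an aromatic carbon. Chloro in place of hydrogen gives a 1.1-fold higher number from compound 1 to compound 2 (0.05 log units; within the scatter). Iodo in place of hydrogen gives no change at the digits printed from compound 1 to compound 3 (within the scatter). Iodo in place of chloro gives a 1.1-fold lower number from compound 2 to compound 3 (0.05 log units; within the scatter). None of them involves trifluoromethyl, so the data offer only an indirect guide. On these three small steps, no change beyond the scatter is expected in this assay, and no direction can be called. The expected step is a 1.0-fold higher number from compound 3 to compound 4 (0.01 log units; within the scatter). Compound 4 is estimated at 4200 nM, with an expected range of 2000 nM to 8500 nM.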

Compound 4, concentration for 50% growth inhibition: 794 nM
For compound 4 the middle estimate is 5.3-fold (0.72 log units) above the measured one; the measured number lies below the stated range.
By their numbers in this assay, from the lowest: compound 4; then compounds 1, 3 and 2 (each within the scatter of the next).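

This aromatic carbon, meta to a large group, looked indifferent while it carried hydrogen, chloro or iodo, but that was true only of those three groups. In this assay, trifluoromethyl gives a 5.2-fold lower number from compound 3 to compound 4 (0.72 log units; beyond the scatter), and the steps from the other two compounds agree: a 5.8-fold lower number from compound 2 to compound 4 (0.76 log units; beyond the scatter) and a 5.2-fold lower number from compound 1 to compound 4 (0.72 log units; beyond the scatter), so among the four compounds shown, the position responds to this one group alone. The data shown offer no measurement that explains why trifluoromethyl stands apart from the other groups.

As far as these compounds go, whether other groups at this carbon, such as a nitrile, a methoxy group or a carboxylic acid, would also move the number remains open. Also open, from the compounds shown here alone, is whether trifluoromethyl would give a similar step at another carbon of the same ring.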